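The compounds below may be only part of what the source reports. "The series", "measured", "known", "first", "only" and "open" are said of these compounds alone.

Measured in a functional assay on 4T1 cells (Homo sapiens) for cytotoxicity, read by MTT assay, with a stated time of 48 h; a lower number here means a stronger inhibitor, a higher number a weaker inhibitor:
- Compound 1 `CCn1c(/C=C2/C(=O)Nc3ccc(F)cc32)nc2ccccc21`: > 50000 nM
- Compound 2 `CC(C)n1c(/C=C2/C(=O)Nc3ccccc32)nc2ccccc21`: 40400 nM

Compound 1 gives > 50000 nM, which is a limit of the assay and not a number. For the measured compounds named here, compound 2, at 40400 nM, therefore holds the only actual number so far. Compound 3 `CC(C)n1c(/C=C2/C(=O)Nc3ccc(F)cc32)nc2ccccc21` differs from compound 2 by fluoro in place of hydrogen on an aromatic carbon. No change in a single place has yet been measured in this assay, so the guide is thin. The expected step, a 1.1-fold lower number from compound 2 to compound 3 (0.03 log units; within the scatter), is small, with no direction beyond the scatter. For compound 3 the estimated value is 38000 nM, with an expected range from 15000 nM to 85000 nM.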

Compound 3, half-maximal inhibitory concentration: 25800 nM
For compound 3 the middle estimate is 1.5-fold (0.17 log units) above the measured one; low and high end bracket the measured number.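

In this assay, fluoro in place of hydrogen on this aromatic carbon gives a 1.6-fold lower number from compound 2 to compound 3 (0.19 log units; within the scatter), so this single change does not move the number beyond the usual scatter. Methyl in place of hydrogen on the saturated chain carbon bound to the aromatic nitrogen gives an at least 1.9-fold lower number from compound 1 to compound 3 (0.28 log units; that floor lies within the scatter), so that step also shows no change beyond the scatter, and its full size stays unknown. Compound 1 stands at a limit and not at a number: the limit of > 50000 nM in this assay, at which 1 of the 3 values shown sits.

Open, going by these compounds, is whether chloro or an amine on this aromatic carbon, or a longer chain on the aromatic nitrogen, would move the number beyond the scatter.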